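Removing the methyl from compound 1

The source may report more compounds than this note shows. Statements on the series, on what has been measured and on what is new or still open speak of the compounds shown alone.

In a functional assay on HCT-116 cells (Homo sapiens) for cytotoxicity, read by scintillation counting and thymidine incorporation, with a stated time of 72 h (a higher number here means a weaker inhibitor, a lower number a stronger inhibitor), compound 1 `CC=C(c1cc(OC)cc(OC)c1)c1ccc(OC)c(O)c1` gives 30 nM, within the scatter of compound 3 `C=C(c1ccc(OC)c(N)c1)c1ccc(OC)c(OCC)c1` at 38 nM, while compound 2 `COc1cc(OC)cc(C(=C(C)C)c2ccc(OC)c(O)c2)c1` reads 970 nM. Compound 4 `C=C(c1cc(OC)cc(OC)c1)c1ccc(OC)c(O)c1` is unmeasured. The change from compound 1 is hydrogen in place of methyl on a double-bonded chain carbon bound to a double-bonded chain carbon. Among the compounds with values here, the one measured step at this carbon is large and adds a methyl: a 32-fold higher number from compound 1 to compound 2 (1.51 log units; beyond the scatter). It runs the opposite way, so it does not fix the size of this removal. Compound 3, with hydrogen at this place but other differences, still reaches 38 nM. No large loss is therefore expected in this assay. The estimated step is a 1.2-fold lower number from compound 1 to compound 4 (0.08 log units; within the scatter), with nothing expected beyond the scatter. For compound 4 the expected value is 25 nM, with an estimated range of 8 nM to 90 nM.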

Compound 4, half-maximal inhibitory concentration: 21 nM
Compound 4: the middle estimate sits 1.2-fold (0.08 log units) above what was measured; the range from low to high includes it.
By their numbers in this assay, from the lowest: compounds 4, 1 and 3 (each within the scatter of the next); then compound 2.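

In this assay, hydrogen in place of methyl on a double-bonded chain carbon bound to a double-bonded chain carbon gives a 1.4-fold lower number from compound 1 to compound 4 (0.15 log units; within the scatter), so this carbon needs no methyl to keep the reading. The sensitivity at this place therefore runs one way among these compounds: removal stays within the scatter, whereas the added methyl gave a 32-fold higher number from compound 1 to compound 2 (1.51 log units; beyond the scatter). No measurement available here accounts for this difference.

From the compounds shown here alone, whether an ethyl group or a longer chain on this carbon reads like compound 1 or like compound 2 remains open. Also open, going by these compounds, is whether the tolerance for hydrogen holds outside this assay.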